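A few compounds are considered here, and "the series" means these few. Any claim that something is new, unique, unknown or untested is made for them only; others in the source may bear on it.

Measured compounds:
compound 1, `O=C1C[C@@H](O[C@H]2O[C@H](CO)[C@@H](O)[C@H](O)[C@H]2O)CN1`, 89000 nM
compound 2, `O=C1C[C@H](O[C@H]2O[C@H](CO)[C@@H](O)[C@H](O)[C@H]2O)CN1`, 80900 nM
compound 3, `O=C1C[C@@H](O[C@H]2O[C@H](CO)[C@@H](O)[C@H](O)[C@@H]2O)CN1`, 108000 nM

In a functional assay on RAW264.7 cells (Mus musculus) for inhibition, read by Griess assay, with a stated time of 24 h (a higher number here means a weaker inhibitor, a lower number a stronger inhibitor), compound 3 gives 108000 nM, and its number sits alongside those of compound 1 and compound 2: the steps of a 1.2-fold higher number from compound 1 to compound 3 (0.08 log units; within the scatter) and a 1.3-fold higher number from compound 2 to compound 3 (0.13 log units; within the scatter) are both within the scatter, as is a 1.1-fold lower number from compound 1 to compound 2 (0.04 log units; within the scatter). Each of these three pairs differs only in the configuration drawn at one or two ring stereocentres, which is the whole content of the fact that compounds 1 and 2 differ only in the configuration as drawn, the fact that compounds 1 and 3 differ only in the configuration as drawn and (the fact that compounds 2 and 3 differ only in the configuration as drawn).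

Compound 4, `O=C1C[C@H](O[C@H]2O[C@H](CO)[C@@H](O)[C@H](O)[C@@H]2O)CN1`, has not yet been measured in this assay. Compared with compound 3 the change is the two compounds have the same atoms and bonds and differ only in configuration as drawn: 1 of 6 stereo elements differ; a stereocentre at a saturated ring carbon is drawn R in compound 3 and S in compound 4. All three measured steps bear on this one, since each of them is a change of configuration at a saturated ring carbon of the same kind, and none of them moved the number beyond the scatter. The expectation is therefore a step of a 1.2-fold lower number from compound 3 to compound 4 (0.07 log units; within the scatter) that stays within the scatter. Compound 4 is estimated to give 92000 nM in this assay, in a range from 50000 nM to 170000 nM.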

Compound 4, half-maximal inhibitory concentration: 67100 nM
Compound 4: the middle estimate sits 1.4-fold (0.14 log units) above what was measured, and the stated range covers the measured number.
By their numbers in this assay, from the lowest: compounds 4, 2, 1 and 3 (each within the scatter of the next).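

Compound 4 fills the fourth combination of configurations at the two ring stereocentres that vary, and in this assay the change at this stereocentre stays within the scatter with the other stereocentre in its second configuration too, with a 1.6-fold lower number from compound 3 to compound 4 (0.21 log units; within the scatter), just as it did in the earlier step with a 1.1-fold lower number from compound 1 to compound 2 (0.04 log units; within the scatter). The other two steps to the new compound also stay within the scatter, with a 1.2-fold lower number from compound 2 to compound 4 (0.08 log units; within the scatter) and a 1.3-fold lower number from compound 1 to compound 4 (0.12 log units; within the scatter), the last of which changes both stereocentres at once, so none of the four combinations separates from the rest. The step at this position involves nothing but the drawn configuration: the fact that compounds 3 and 4 differ only in the configuration as drawn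

All four compounds share the same atoms and bonds. They leave open what an amine in place of a hydroxyl, or a carboxylic acid or a longer chain on the shared core, would do to the number.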